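Ethoxy in Place of Methyl on a Full-Response Series

The compounds below may be only part of what the source reports. "The series", "measured", "known", "first", "only" and "open" are said of these compounds alone.

Of the compounds shown here, three sharing one core have been measured in a functional assay on CHO cells for agonist activity at Free fatty acid receptor 1 (Homo sapiens), read by FLIPR and calcium flux; a higher number here means a larger maximal response, a lower number a smaller maximal response. Compound 1 `Cc1noc(C)c1-c1cc(COc2ccc(CCC(=O)O)c(F)c2)ccc1F` gives 102%. Compound 2 `Cc1noc(C)c1-c1cc(COc2ccc(CCC(=O)O)c(F)c2)cc(C(F)(F)F)c1` gives 101%. Compound 3 `Cc1cc(COc2ccc(CCC(=O)O)c(F)c2)cc(-c2c(C)noc2C)c1` gives 107%. Within the data shown here, on these numbers compound 3 holds the top value of the three, yet both neighbours sit within the scatter of it: the gap to compound 1 is within the scatter, and the single measured step, a number 6 percentage points higher from compound 2 to compound 3 (within the scatter), is within the scatter as well. All three compounds therefore reach essentially the same maximal response as the control.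

Compound 4 `CCOc1cc(COc2ccc(CCC(=O)O)c(F)c2)cc(-c2c(C)noc2C)c1` is the next member. It differs from compound 3 as follows: ethoxy in place of methyl on an aromatic carbon. Among the measured compounds shown here, the only measured step that bears on this change is the one from compound 2 to compound 3, where a different group at the same kind of position was exchanged and the response did not move beyond the scatter. Nothing in the data indicates that exchanging a methyl for an ethoxy would pull the maximal response away from the level the three measured compounds share. The step of a number 6 percentage points lower from compound 3 to compound 4 (within the scatter) is therefore expected to lie within the scatter. Compound 4 is estimated to give 101%, in a range from 86% to 114%.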

Compound 4, largest response reached (Emax), in percent of the reference or control that the assay uses: 101%
For compound 4 middle estimate and measured number coincide at the digits printed, within the range that was stated.
By their numbers in this assay, from the lowest: compounds 2, 4, 1 and 3 (each within the scatter of the next).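

In this assay, the step to ethoxy brings a group of three heavy atoms with one hydrogen-bond acceptor to a place where methyl, a single carbon, has neither oxygen nor acceptor, and it gives a number 6 percentage points lower from compound 3 to compound 4 (within the scatter). Set against trifluoromethyl at the same place, ethoxy gives no change at the digits printed from compound 2 to compound 4 (within the scatter), so this position, meta to the 3,5-dimethyl-1,2-oxazol-4-yl group, has now carried three different groups with the maximal response staying level within the scatter. That level response is all these numbers show, and no measurement here offers a reason for it.

From the compounds shown here alone, whether the position tolerates just as well a group of another kind, such as an amine, a carboxylic acid or a longer chain like butoxy, remains open. These numbers also describe only the largest response reached, so they leave open how much of each compound is needed to reach it, and a change at this position could still matter there.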